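Methylsulfanyl for methoxy on the aromatic ring

The source may report more compounds than this note shows. Statements on the series, on what has been measured and on what is new or still open speak of the compounds shown alone.

Working values from a functional assay on Jurkat cells (Homo sapiens) for antiproliferative activity, read by MTT assay, with a stated time of 72 h (on this read-out higher numbers stand for weaker inhibition and lower numbers for stronger inhibition), are as follows

- compound 1 `COc1cc(C(=O)c2sc3ccccc3c2-c2ccccc2)cc(OC)c1OC` gives 1500 nM
- compound 2 `COc1cc(C(=O)c2sc3ccccc3c2-c2ccc(F)cc2)cc(OC)c1OC` gives 2300 nM
- compound 3 `COc1ccc(-c2c(C(=O)c3cc(OC)c(OC)c(OC)c3)sc3ccccc23)cc1` gives 1600 nM

Compound 3, at 1600 nM, lies within the scatter of both other compounds, so the three values do not separate. Compound 4 `COc1cc(C(=O)c2sc3ccccc3c2-c2ccc(SC)cc2)cc(OC)c1OC` is the next case, with the change (methylsulfanyl in place of methoxy on an aromatic carbon). This places methylsulfanyl in place of methoxy on an aromatic carbon, para to a large group.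

Among the measured compounds shown here, no measured step involves methylsulfanyl, so the evidence is indirect. For the measured compounds named here, three steps bear on this same place: a 1.5-fold higher number from compound 1 to compound 2 (0.19 log units; within the scatter), a 1.1-fold higher number from compound 1 to compound 3 (0.03 log units; within the scatter) and a 1.4-fold lower number from compound 2 to compound 3 (0.16 log units; within the scatter). Hydrogen, fluoro and methoxy there have so far produced no step beyond the scatter, though three compounds are a narrow basis.

The step expected in this assay is a 1.1-fold higher number from compound 3 to compound 4 (0.03 log units; within the scatter), with no shift in a particular direction and no change beyond the scatter anticipated. Compound 4 is estimated at 1700 nM, with an expected range from 800 nM to 3600 nM.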

Compound 4, half-maximal inhibitory concentration: 1900 nM
Compound 4: the middle estimate sits 1.1-fold (0.05 log units) below what was measured; measured number inside the range.
By their numbers in this assay, from the lowest: compounds 1, 3, 4 and 2 (each within the scatter of the next).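

In this assay, methylsulfanyl on an aromatic carbon para to a large group does not separate from methoxy (a 1.2-fold higher number from compound 3 to compound 4 (0.07 log units; within the scatter)), from fluoro (a 1.2-fold lower number from compound 2 to compound 4 (0.08 log units; within the scatter)) or from hydrogen (a 1.3-fold higher number from compound 1 to compound 4 (0.10 log units; within the scatter)). The insensitivity seen across three groups therefore extends to a fourth, and to a sulfur-containing group in particular, with all four values lying within the scatter of their neighbours in the order. No measurement shown bears on why these values stay together.

From the compounds shown here alone, whether an amine, a carboxylic acid or a longer chain such as butoxy at this place would give a step beyond the scatter remains open. Also open, going by these compounds, is whether methylsulfanyl in place of methoxy would read the same at another place on this ring, since all four compounds differ at this one place only.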